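The source may report more compounds than this note shows. Statements on the series, on what has been measured and on what is new or still open speak of the compounds shown alone.

Measured compounds:
compound 1 `COC(=O)c1ccc(NCc2cncn2Cc2ccccc2Cl)cc1-c1ccccc1` – 10000 nM
compound 2 `CC(C)c1ccc(Cn2cncc2CNc2ccc(-c3nc4ccccc4s3)c(-c3ccccc3)c2)cc1` – > 1000 nM

Among the measured compounds shown here, in a toxicity assay on NIH3T3 cells (Mus musculus) for cytotoxicity, read by resazurin assay (a lower number here means that less compound is needed, a higher number that more compound is needed for the effect), compound 1 gives 10000 nM, the only plain number in this set. For compound 2 this assay reports only a limit, > 1000 nM. That leaves one bare anchor: the limit of > 1000 nM in this assay, at which 1 of the 2 values shown sits.

Compound 3 `COC(=O)c1ccc(NCc2cncn2Cc2cccc(N)c2)cc1-c1ccccc1` follows from compound 1 by one change, (3-aminophenyl in place of 2-chlorophenyl on a saturated chain carbon bound to an aromatic nitrogen). For the measured compounds named here, no measured step of this kind exists here, so the expected step of no change at the digits printed from compound 1 to compound 3 (within the scatter) is no more than the usual scatter, in no set direction. Compound 3 is therefore expected to sit near 10000 nM, within 3000 nM to 30000 nM, and a limit rather than a number remains a real possibility.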

Compound 3, half-maximal effective concentration: > 10000 nM
Compound 3: no number, only a limit; the forecaster's own chance of this, stated with the estimate: 40%; the middle value sits exactly at the limit.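

In this assay, 3-aminophenyl in place of 2-chlorophenyl on a saturated chain carbon bound to an aromatic nitrogen gives a number no lower from compound 1 to compound 3 (the limit leaves the size open). Compound 3 carries only a limit, not a number: the limit of > 10000 nM in this assay, at which 1 of the 3 values shown sits. This position therefore takes the change without any lower number appearing, though the size of the step stays unreadable.

From the compounds shown here alone, whether the step follows the loss of the chlorine or the gain of the amino group stays open, as does a plain number for compound 3. Going by these compounds, how a carboxylic acid or a longer chain would read at this place is also open.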